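This account rests on a few compounds, and the source may have more. Where it says the series, first, only, none or still open, it means among the compounds named here.

Compound 1 `Cc1cc(C)cc(S(=O)(=O)c2c(C(=O)NCC(=O)NC(C)c3ccccc3)[nH]c3ccc(Cl)cc23)c1`: 29400 nM
Compound 2 `Cc1cc(C)cc(S(=O)(=O)c2c(C(=O)NC(c3ccc(Cl)cc3)C3CC3)[nH]c3ccc(Cl)cc23)c1`: > 47300 nM, a limit
Compound 3 `Cc1cc(C)cc(S(=O)(=O)c2c(C(=O)NC(C)c3ccco3)[nH]c3ccc(Cl)cc23)c1`: > 54700 nM, a limit

For the measured compounds named here, in an ADME assay on MT4 cells (Homo sapiens) for cytotoxicity, read by MTT assay (on this read-out higher numbers stand for lower toxicity in this test and lower numbers for higher toxicity in this test), compound 1 gives 29400 nM, the only plain number among the three results. Compound 2 reaches a limit of > 47300 nM. Compound 3 reaches a limit of > 54700 nM. Compound 4 `Cc1cc(C)cc(S(=O)(=O)c2c(C(=O)NC(C)c3ccccc3F)[nH]c3ccc(Cl)cc23)c1` differs from compound 1 in one place: 1-(2-fluorophenyl)ethyl in place of ((1-phenylethyl)carbamoyl)methyl on an amide-type nitrogen. Going by the values given here, two measured steps bear on this change, each replacing the same group on the amide-type nitrogen: an at least 1.6-fold higher number from compound 1 to compound 2 (0.20 log units; that floor lies within the scatter) and an at least 1.8-fold higher number from compound 1 to compound 3 (0.26 log units; that floor lies within the scatter). Both reach only a floor that lies within the scatter. A step of a 1.5-fold higher number from compound 1 to compound 4 (0.18 log units; within the scatter) is therefore expected, a rise in the number that need not exceed the scatter and may end at a limit. Compound 4 is estimated at 45000 nM, between 25000 nM and 80000 nM.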

Compound 4, half-maximal cytotoxic concentration: > 51500 nM
Compound 4 gave a limit, no number; the forecaster's own chance of this, stated with the estimate: 50%; at least 1.1-fold (0.05 log units) between middle value and limit.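

In this assay, putting 1-(2-fluorophenyl)ethyl in place of ((1-phenylethyl)carbamoyl)methyl gives an at least 1.7-fold higher number from compound 1 to compound 4 (0.24 log units; that floor lies within the scatter). The entering group has 0 hydrogen-bond donors and 0 hydrogen-bond acceptors, and it is the third group on this amide-type nitrogen to end at a limit. Compound 4 gives a limit and not a number: the limit of > 51500 nM in this assay, at which 1 of the 4 values shown sits.

The steps joining compound 4 to compounds 2 and 3 cannot be read. Going by these compounds, how far the number rises remains open, as does the result for a group on this nitrogen carrying an amine or a carboxylic acid.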